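A Methyl Moved onto the Aromatic Ring

The source may report more compounds than this note shows. Statements on the series, on what has been measured and on what is new or still open speak of the compounds shown alone.

Compound 1, `C[C@H]1Cc2cc(C(N)=O)cnc2N1`, in an assay on isolated protein for inhibition of Nicotinamide N-methyltransferase (Homo sapiens), read by luminescence, with a stated time of 20 min; on this read-out lower numbers stand for stronger inhibition and higher numbers for weaker inhibition: > 10000 nM, which is a limit of the assay and not a number.
Compound 2, `C[C@@H]1Cc2cc(C(N)=O)cnc2N1`: 42 nM.
Compound 3, `NC(=O)c1cnc2c(c1)CCN2`: 175 nM.

Compound 3 is the bare core; of the two real numbers shown it has the higher one, and the nearest is compound 2, as the step of a 4.2-fold higher number from compound 2 to compound 3 (0.62 log units; beyond the scatter) shows. Compound 1 sits at a limit, and the contrast with compound 2 rests on the fact that compounds 1 and 2 differ only in the configuration as drawn and (the limit of > 10000 nM in this assay, at which 1 of the 3 values shown sits).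

Compound 4, `Cc1c(C(N)=O)cnc2c1CCN2`, differs from compound 3 by methyl in place of hydrogen on an aromatic carbon. Within the data shown here, no measured step places a methyl on an aromatic carbon; the two steps that involve a methyl, a 4.2-fold higher number from compound 2 to compound 3 (0.62 log units; beyond the scatter) and an at least 57-fold lower number from compound 1 to compound 3 (1.75 log units; beyond the scatter), both concern a saturated ring carbon and show that the same group can help or hurt greatly depending on where it sits. They therefore offer only a loose guide. With the methyl entering ortho to the carbamoyl group, a modest weakening is expected rather than a gain, so the estimated step is a 2.3-fold higher number from compound 3 to compound 4 (0.36 log units; beyond the scatter). Compound 4 is estimated at 400 nM, with a range from 80 nM to 3000 nM.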

Compound 4, half-maximal inhibitory concentration: 102 nM
For compound 4 the middle estimate is 3.9-fold (0.59 log units) above the measured one, within the range that was stated.
By their numbers in this assay, from the lowest: compound 2; then compounds 4 and 3 (each within the scatter of the next). At a limit, above all of these: compound 1.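

In this assay, methyl in place of hydrogen on this aromatic carbon, ortho to a carbamoyl group and opposite the ring nitrogen, gives a 1.7-fold lower number from compound 3 to compound 4 (0.23 log units; within the scatter), so the change cannot be told apart from no change at all. The earlier steps shown here involving a methyl concerned only a saturated ring carbon, where both steps lay beyond the scatter and ranged from modest to large depending on the compounds compared. Among these compounds, this new step is the first reading at an aromatic carbon, and it shows that the core of compound 3 can carry a methyl at this position with no readable loss of inhibition, although a single small group gives only a narrow view of the position.

On these data alone, what an ethyl group, a methoxy group or an amine would do on this carbon stays open, as does the outcome of pairing this methyl with the saturated-ring methyl drawn R in compound 2. The information at hand concerns the other methyl position and the limit reached by compound 1, and nothing in it explains the result at this aromatic carbon.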